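The compounds below may be only part of what the source reports. "The series", "measured", "known", "first", "only" and "open" are said of these compounds alone.

Measured so far:
- compound 1, `COc1ccc(OCCCOc2cc(=O)n(CCCO)c3c2CC(CC=C(C)C)C(C)(C)C3)cc1`, 4.1%
- compound 2, `CC(C)=CCC/C(C)=C/COc1cc(=O)n(CCCO)c2c1CC(C/C=C(\C)CCC=C(C)C)C(C)(C)C2`, 3.1%
- compound 3, `COc1ccc(C(=O)NCCCOc2cc(=O)n(CCCO)c3c2CC(C/C=C(\C)CCC=C(C)C)C(C)(C)C3)cc1`, 14.1%

In a functional assay on PANC-1 cells (Homo sapiens) for inhibition, read by MTT assay, with a stated time of 24 h, tested at 10 uM (on this read-out lower numbers stand for less inhibition and higher numbers for more inhibition at the one concentration tested (going by the name of the read-out)), compound 3 gives the highest of the three numbers. Its nearest neighbour is compound 1, whose number lies within the usual scatter of compound 3, so no order between these two can be read from the data. Compound 2 sits further off, beyond the scatter, so compound 3 does show more inhibition than compound 2.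

Compound 4, `COc1ccc(OCCCOc2cc(=O)n(CCCO)c3c2CC(C/C=C(\C)CCC=C(C)C)C(C)(C)C3)cc1`, has not yet been measured in this assay. It differs from compound 3 in one place: 4-methoxyphenoxy in place of ((4-methoxyphenyl)carbonyl)amino on a saturated chain carbon, three bonds along the chain from an oxygen on an aromatic ring. The group that leaves carries the one hydrogen-bond donor of the pair; the group that enters has none. Compound 1 carries the same 4-methoxyphenoxy group and gives 4.1% in this assay, while its core differs from that of compound 4 elsewhere, so it offers only a loose hint.

Given that, compound 4 is expected to land lower than compound 3, with a step of a number 8.1 percentage points lower from compound 3 to compound 4 (within the scatter) that may stay inside the scatter. The estimate for compound 4 in this assay is 6%, with a range from 0% to 17%.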

Compound 4, a percentage reported as inhibition, at one concentration (the size of the read-out at that concentration, not a potency): 0%
The estimate for compound 4 lay 6 percentage points above the measured number; the measured number falls inside the stated range.
By their numbers in this assay, from the lowest: compounds 4, 2, 1 and 3 (each within the scatter of the next, the first and the last beyond it).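

In this assay, putting 4-methoxyphenoxy in place of ((4-methoxyphenyl)carbonyl)amino on a saturated chain carbon, three bonds along the chain from an oxygen on an aromatic ring, gives a number 14.1 percentage points lower from compound 3 to compound 4 (beyond the scatter) with the rest of the molecule unchanged. This single change shows that the group at this position can shift the read-out beyond the usual scatter, although compound 3 itself reaches only 14.1% at the one concentration tested. The other two changes give no such evidence: 2-(4-methoxyphenoxy)ethyl in place of 2,6-dimethylhepta-1,5-dien-1-yl gives a number 3.1 percentage points lower from compound 2 to compound 4 (within the scatter) and 3-methylbut-2-en-1-yl in place of hydrogen gives a number 4.1 percentage points lower from compound 1 to compound 4 (within the scatter) so neither can be told apart from no change here.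

Still open, from the compounds shown here alone, is whether the amide hydrogen matters in itself, which a methyl on the amide nitrogen would address, and whether an amine, a carboxylic acid or a longer chain at this position would give a number different from that of compound 3. No measurement shown here explains why the groups differ.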